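The source may hold more compounds than are shown below. What is called first, only, known or untested is meant among the compounds shown, and "the series" means these compounds.

Measured in an assay for binding affinity to 5-hydroxytryptamine receptor 1F (Homo sapiens), read by radioligand binding; on this read-out lower numbers stand for stronger inhibition and higher numbers for weaker inhibition:
compound 1 `CCCCCC(=O)Nc1ccc2[nH]cc(C3CCN(C)CC3)c2n1`: 13 nM
compound 2 `CCCCCCCC(=O)Nc1ccc2[nH]cc(C3CCN(C)CC3)c2n1`: 20 nM
compound 3 `COc1ccccc1C(=O)Nc1ccc2[nH]cc(C3CCN(C)CC3)c2n1`: 20 nM

Compound 3 stands level with compound 2 at the digits shown, the two together giving the highest numbers of the three, and compound 1 is the furthest from it, though still within the scatter. The change from compound 3 to compound 4 `CN1CCC(c2c[nH]c3ccc(NC(=O)C4CCCCC4)nc23)CC1` is cyclohexyl in place of 2-methoxyphenyl on a carbonyl carbon. The measured steps that bear on it are a 1.5-fold higher number from compound 1 to compound 3 (0.19 log units; within the scatter) and no change at the digits printed from compound 2 to compound 3 (within the scatter): both are exchanges of the group on the carbonyl carbon, and both lie within the scatter. No shift beyond the scatter is therefore expected in this assay. Compound 4 is expected to give 16 nM, between 6 nM and 45 nM. The expected step is a 1.3-fold lower number from compound 3 to compound 4 (0.10 log units; within the scatter).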

Compound 4, inhibition constant: 20 nM
Compound 4: the middle estimate sits 1.3-fold (0.10 log units) below what was measured; the measured number falls inside the stated range.
By their numbers in this assay, from the lowest: compounds 1, 2, 3 and 4 (each within the scatter of the next).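

In this assay, a non-aromatic ring on the carbonyl carbon reads the same as the six-membered aromatic ring of 2-methoxyphenyl (no change at the digits printed from compound 3 to compound 4 (within the scatter)). The open chains give the same picture (no change at the digits printed from compound 2 to compound 4 (within the scatter); a 1.5-fold higher number from compound 1 to compound 4 (0.19 log units; within the scatter)), so cyclohexyl, 2-methoxyphenyl, pentyl and heptyl all lie within the scatter of one another at this place. Nothing available here accounts for this result.

As far as these compounds go, whether a group carrying an amine or a carboxylic acid on the carbonyl carbon would stay within that scatter remains open. The same holds for a group as small as methyl there.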